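A few compounds are considered here, and "the series" means these few. Any claim that something is new, unique, unknown or untested is made for them only; others in the source may bear on it.

Measured so far:
- compound 1 `N/C(=N\O)c1ccc(S(=O)(=O)C2=C(c3ccccc3)OC(c3ccccc3)(c3ccccc3)C2)cc1`: 37900 nM
- compound 2 `N/C(=N\O)c1ccc(C2=C(S(=O)(=O)c3ccc(/C(N)=N/O)cc3)CC(c3ccccc3)(c3ccccc3)O2)cc1`: 119000 nM
- compound 3 `N/C(=N\O)c1ccc(Nc2ccc(C3=C(S(=O)(=O)c4ccc(/C(N)=N/O)cc4)CC(c4ccccc4)(c4ccccc4)O3)cc2)cc1`: 48900 nM

In an ADME assay on THP-1 cells (Homo sapiens) for cytotoxicity, read by flow cytometry, with a stated time of 72 h (a higher number here means a weaker inhibitor, a lower number a stronger inhibitor), compound 2 gives 119000 nM, the highest of the three numbers: compound 3 sits at a 2.4-fold lower number from compound 2 to compound 3 (0.39 log units; beyond the scatter) and compound 1 at a 3.1-fold higher number from compound 1 to compound 2 (0.50 log units; beyond the scatter). Compound 4 `N/C(=N\O)c1ccc(C2=C(S(=O)(=O)c3ccc(Nc4cccc(/C(N)=N/O)c4)cc3)CC(c3ccccc3)(c3ccccc3)O2)cc1` has not been measured. Compared with compound 2 the change is a group of 11 heavy atoms (7 carbon, 3 nitrogen, 1 oxygen; one six-membered aromatic ring of carbon only) in place of a group of 4 heavy atoms (1 carbon, 2 nitrogen, 1 oxygen; no ring), on an aromatic carbon.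

Among the measured compounds shown here, the step that bears on this is the one from compound 2 to compound 3, which also replaces the group of 4 heavy atoms with a group of 11 heavy atoms on an aromatic carbon and gave a 2.4-fold lower number from compound 2 to compound 3 (0.39 log units; beyond the scatter). The entering group of compound 4 is not the same as that of compound 3, so the step cannot be copied exactly, but its size and kind are the nearest guide. The step from compound 1 to compound 3, a 1.3-fold higher number from compound 1 to compound 3 (0.11 log units; within the scatter), shows that a group of this kind on the core of compound 1 leaves the number close to where it was. Accordingly a modest lowering, of about the size seen from compound 2 to compound 3, is expected: a 2.2-fold lower number from compound 2 to compound 4 (0.34 log units; beyond the scatter). For compound 4 in this assay the estimate is 55000 nM, with a range of 25000 nM to 130000 nM.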

Compound 4, half-maximal inhibitory concentration: > 50000 nM
Compound 4: only a limit was reported; the forecaster's own chance of this, stated with the estimate: 10%; the middle value is on the limit's open side.
By their numbers in this assay, from the lowest: compounds 1 and 3 (each within the scatter of the next); then compound 2.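

In this assay, among the compounds shown here, compound 4 gives > 50000 nM, which is a limit and not a number, so no step from compound 2 to compound 4 can be read. The compounds shown leave open where compound 4 stands relative to compound 2, and whether this group of 11 heavy atoms changes the number at all.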